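This account rests on a few compounds, and the source may have more. Where it says the series, first, only, none or still open, it means among the compounds named here.

In a functional assay on HeLa cells (Homo sapiens) for antiproliferative activity, read by MTT assay, with a stated time of 48 h (on this read-out lower numbers stand for stronger inhibition and higher numbers for weaker inhibition), compound 3 (`COC(=O)CNC(=O)c1ccc(Oc2nc3ccccc3nc2NC(C)(C)C)cc1`) gives > 50000 nM, which is a limit of the assay and not a number. Compound 1 (`CC[C@@H](C)[C@H](NC(=O)c1ccc(Oc2nc3ccccc3nc2C)cc1)C(=O)OC`) gives > 50000 nM, which is likewise a limit. Together they make up (the limit of > 50000 nM in this assay, at which 2 of the 3 values shown sit). Going by the values given here, the only other value comes from compound 2 (`CC[C@@H](C)[C@H](NC(=O)c1ccc(Oc2nc3ccccc3nc2C)cc1)C(=O)O`), at 33200 nM. Compound 3 therefore has no measured number of its own, and the data show only that it stands at the limit.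

Compound 4 (`COC(=O)[C@H](CC(C)C)NC(=O)c1ccc(Oc2nc3ccccc3nc2NC(C)(C)C)cc1`) differs from compound 3 by isobutyl in place of hydrogen on a saturated chain carbon bound to an amide-type nitrogen and a carbonyl carbon, which places isobutyl in place of hydrogen on a saturated chain carbon bound to an amide-type nitrogen and a carbonyl carbon. Among the compounds with values here, no measured step covers this change. Within the data shown here, the one step available is an at least 1.5-fold lower number from compound 1 to compound 2 (0.17 log units; that floor lies within the scatter), which concerns a different part of the molecule and so gives only indirect guidance. Its size offers no support for a large move in this assay, so no step beyond the scatter is expected, and a result at the limit remains quite likely.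

For compound 4 the expected value is 40000 nM, with an estimated range of 12000 nM to 90000 nM. This estimate corresponds to an expected at least 1.2-fold lower number from compound 3 to compound 4 (0.09 log units; that floor lies within the scatter).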

Compound 4, half-maximal inhibitory concentration: > 50000 nM
Compound 4 was reported as a limit (the forecaster's own chance of this, stated with the estimate: 60%); middle value at least 1.2-fold (0.09 log units) away from the limit.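

In this assay, going by these compounds alone, compound 4 stands at a limit of the assay, as compound 3 does, so no step can be read between compound 3 and compound 4, and the result adds only one more compound to that limit: the limit of > 50000 nM in this assay, at which 3 of the 4 values shown sit. The compounds shown leave open whether isobutyl in place of hydrogen at this saturated chain carbon changes the read-out at all.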